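Working notes: three measured compounds, one pending

The source may report more compounds than this note shows. Statements on the series, on what has been measured and on what is new or still open speak of the compounds shown alone.

The series is followed in a functional assay (Oryctolagus cuniculus) for inhibition; on this read-out lower numbers stand for stronger inhibition and higher numbers for weaker inhibition. Compound 1, `CC(=O)OCCOCn1cnc2c(Cl)nc(Cl)nc21`, gives 10 ug/mL in this assay. Compound 3, `Nc1nc2c(nc(O)n2COCCO)c(=O)[nH]1`, gives 48 ug/mL in this assay. Compound 2, `Cc1nc2c(O)nc(N)nc2n1COCCO`, reaches only a limit of this assay, reported as > 400 ug/mL. That limit marks the weak end of the numbers shown: the limit of > 400 ug/mL in this assay, at which 1 of the 3 values shown sits. Among the measured compounds shown here, no two measured compounds differ in a single place, so no measured step is available to lean on.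

Compound 4, `Nc1nc(O)c2nc(N3CCCCC3)n(COCCO)c2n1`, has not been measured. It differs from compound 2 by piperidin-1-yl in place of methyl on an aromatic carbon. Compound 1 and compound 3 differ from compound 2 in several places at once, so their values say nothing direct about this single change.

The expected step is an at least 1.6-fold lower number from compound 2 to compound 4 (0.20 log units; that floor lies within the scatter), a modest move toward stronger inhibition that may still leave the reading at or near the limit. For compound 4 the estimate in this assay is 250 ug/mL, within a range from 50 ug/mL to 800 ug/mL, with a real chance that only a limit is again reported.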

Compound 4, concentration for 50% inhibition: 250 ug/mL
Compound 4: middle estimate and measured number agree at the digits printed; low and high end bracket the measured number.
By their numbers in this assay, from the lowest: compound 1; then compound 3; then compound 4. At a limit, above all of these: compound 2.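

In this assay, this aromatic carbon between two ring nitrogen atoms now has its first single-place comparison, as piperidin-1-yl in place of methyl gives an at least 1.6-fold lower number from compound 2 to compound 4 (0.20 log units; that floor lies within the scatter). Among the compounds shown here, with the larger ring-bearing group at this position, compound 4 gives a numerical reading of 250 ug/mL, something the earlier compounds could not show, as none of them differed from another in one place only. The reading for compound 2 is a limit and not a number, so the step has only a floor and its true size remains unknown: the limit of > 400 ug/mL in this assay, at which 1 of the 4 values shown sits.

Still open, going by these compounds, is whether an open-chain amine such as dimethylamino at this carbon would read like piperidin-1-yl or like methyl. The compounds shown also leave open how a carboxylic acid at this position would read.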